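The compounds below may be only part of what the source reports. "The series", "measured", "known", "first", "only" and "open" are said of these compounds alone.

Working notes on the series, read in an ADME assay on L1210/0 cells (Mus musculus) for cytotoxicity, with a stated time of 48 h; a lower number here means a stronger inhibitor, a higher number a weaker inhibitor. Compound 1 `CC1(C)[C@@H](Cn2cnc3c(O)nc(N)nc32)CC[C@@]1(C)CO` gives only a limit, > 200000 nM, and so has no number to compare; the limit of > 200000 nM in this assay, at which 1 of the 3 values shown sits, is the only such case among the three measured compounds.

Compound 2 `O=C1O/C(=C\Cn2ccc(=O)[nH]c2=O)C(OCc2ccccc2)=C1OCc1ccccc1` gives 12900 nM. Compound 3 `COC1=C(OC)/C(=C/Cn2cnc3c(Cl)ncnc32)OC1=O` gives 14000 nM, the higher of the two numbers as they stand, though the two values lie within the scatter of each other. Compound 3 therefore sits level with compound 2 and is the reference point for the next comparison.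

Compound 4 `COC1=C(OCc2ccc([N+](=O)[O-])cc2)C(=O)O/C1=C\Cn1cnc2c(Cl)ncnc21` has not yet been measured in this assay. Its difference from compound 3 is 4-nitrophenyl in place of hydrogen on a saturated chain carbon bound to an oxygen on an unsaturated carbon. In words, 4-nitrophenyl stands in place of hydrogen on a saturated chain carbon bound to an oxygen on an unsaturated carbon.

Within the data shown here, the series offers no measured step between compounds differing in one place, so the size of this change has no direct precedent. The expectation stays anchored on compound 3 at 14000 nM. A modest move towards a lower number is expected, and a result within the scatter would not be surprising. The estimated change is a 1.8-fold lower number from compound 3 to compound 4 (0.24 log units; within the scatter).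

For compound 4 the estimated value is 8000 nM, with an expected range of 2500 nM to 30000 nM.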

Compound 4, half-maximal inhibitory concentration: 13600 nM
Estimate against measurement, compound 4: 1.7-fold (0.23 log units) below; the range from low to high includes it.
By their numbers in this assay, from the lowest: compounds 2, 4 and 3 (each within the scatter of the next). At a limit, above all of these: compound 1.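

In this assay, the saturated chain carbon bound to an oxygen on an unsaturated carbon now has its first measured step, methyl to 4-nitrobenzyl: a 1.0-fold lower number from compound 3 to compound 4 (0.01 log units; within the scatter). The earlier compounds shown here offered no step between compounds differing in one place, whereas this pair shows that a 4-nitrophenyl of 9 heavy atoms, carrying one six-membered aromatic ring, can stand at this place on the shared core with the two values level within the scatter. Nothing measured here accounts for this result.

On these data alone, it remains open whether a different group at this place, such as an amine or a carboxylic acid in place of the nitro group on the benzyl ring, or a longer chain between the oxygen and the ring, would give a step beyond the scatter. The reading also rests on a single pair, so whether methyl to 4-nitrobenzyl reads the same way on another core is open as well.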